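This account rests on a few compounds, and the source may have more. Where it says the series, first, only, none or still open, it means among the compounds named here.

Compound 1 `COC[C@@H](C(C)C)C(c1ccc(O)c(OC)c1)c1ccc(O)c(OC)c1` is one of three diaryl compounds that share a core and differ only in the saturated chain carbon bound to two aromatic carbons. In a functional assay on HL-60 cells (Homo sapiens) for cytotoxicity, read by WST assay, with a stated time of 48 h (a lower number here means a stronger inhibitor, a higher number a weaker inhibitor), compound 1 gives 54000 nM, the highest of the two numbers that are reported as numbers; its nearest neighbour is compound 2 `COc1cc(C(c2ccc(O)c(OC)c2)[C@H](C)[C@@H](C)CF)ccc1O`, which in this assay gives 45000 nM, a difference that is a 1.2-fold lower number from compound 1 to compound 2 (0.08 log units; within the scatter). Compound 3 `COc1cc(C(c2ccc(O)c(OC)c2)[C@H](CO)C(C)C)ccc1O`, carrying 1-(hydroxymethyl)-2-methylpropyl, reaches only a limit of this assay, > 100000 nM. The step from compound 1 to compound 3 is an at least 1.8-fold higher number from compound 1 to compound 3 (0.26 log units; that floor lies within the scatter), and the step from compound 2 to compound 3 is an at least 2.2-fold higher number from compound 2 to compound 3 (0.34 log units; beyond the scatter); both rest on the limit (the limit of > 100000 nM in this assay, at which 1 of the 3 values shown sits).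

Compound 4 `COc1cc(C(c2ccc(O)c(OC)c2)[C@@H](CO)C(C)C)ccc1O` differs from compound 1 by hydrogen in place of methyl on an oxygen on a saturated carbon. The step from compound 1 to compound 3 is the one that most resembles this change, since it also replaces methoxymethyl with hydroxymethyl, and it ran towards a weaker number and a limit. Compound 4 is therefore expected to show a step of a 1.9-fold higher number from compound 1 to compound 4 (0.27 log units; within the scatter), with a fair chance that this assay again reports only a limit. For compound 4 the estimate in this assay is 100000 nM, within a range from 45000 nM to 250000 nM.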

Compound 4, half-maximal inhibitory concentration: > 100000 nM
Compound 4 gave a limit, no number; the forecaster's own chance of this, stated with the estimate: 50%; the middle value lies on the limit itself.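

Compound 4 repeats the hydroxymethyl chain of compound 3 in the other drawn configuration, and neither form gives a number in this assay: the fact that compounds 3 and 4 differ only in the configuration as drawn

Replacing methoxy with hydroxy on the chain of compound 1 gives an at least 1.8-fold higher number from compound 1 to compound 4 (0.26 log units; that floor lies within the scatter), so even with a second compound the floor of this change does not clear the scatter, and a real loss against compound 1 is not established, while the comparison with the fluoromethyl chain gives an at least 2.2-fold higher number from compound 2 to compound 4 (0.34 log units; beyond the scatter), which does clear it. The step between compound 3 and compound 4 cannot be read, and the effect of configuration with this chain therefore stays hidden: the limit of > 100000 nM in this assay, at which 2 of the 4 values shown sit.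

On these data alone, how far the two hydroxymethyl compounds lie past that limit, and so whether the configuration at this saturated chain carbon matters at all, remains open. Also open, as far as these compounds go, is what an aminomethyl or an ethoxymethyl group in place of methoxymethyl on the same chain would give in this assay.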